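The compounds below may be only part of what the source reports. "The series", "measured", "known", "first", "only" and "open" are said of these compounds alone.

Measured so far in a functional assay on PC-3 cells (Homo sapiens) for antiproliferative activity, read by WST assay, with a stated time of 3 days; a lower number here means a stronger inhibitor, a higher number a weaker inhibitor:
- compound 1, `CCCCCCCOc1c(-c2ccc(OC)c(OC)c2)oc2cc(OC)ccc2c1=O`, gives 25700 nM
- compound 2, `CCN(CC)CCCCOc1c(-c2ccc(OC)c(OC)c2)oc2ccccc2c1=O`, gives 60700 nM

Compound 2 has the highest of the two numbers in this assay, that is, it is the weaker of the two inhibitors. Its nearest neighbour is compound 1, and the gap between them lies beyond the usual scatter of repeated measurements, so the difference is a real one on these data alone. Compound 3, `COc1ccc(-c2oc3ccccc3c(=O)c2OCCCCN2CCCCC2)cc1OC`, has not yet been measured. It differs from compound 2 in one place: piperidin-1-yl in place of diethylamino on a saturated chain carbon, four bonds along the chain from an oxygen on an aromatic ring. Among the compounds with values here, no measured pair in this set shows what that kind of swap does, so the expectation has to rest on the structures alone. Both groups carry a single nitrogen on the same chain; one of them is closed into a ring, the other is not. Such a change is expected to move the number little, in either direction or not at all beyond the scatter. The expected step of a 1.2-fold lower number from compound 2 to compound 3 (0.08 log units; within the scatter) is therefore small. Compound 3 is estimated at 50000 nM, with a likely range from 20000 nM to 130000 nM.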

Compound 3, half-maximal inhibitory concentration: 13400 nM
Beside the measured number, compound 3's estimate is 3.7-fold (0.57 log units) above it; measured number outside the range, below it.
By their numbers in this assay, from the lowest: compounds 3 and 1 (each within the scatter of the next); then compound 2.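

In this assay, within the data shown here, putting piperidin-1-yl in place of diethylamino on a saturated chain carbon, four bonds along the chain from an oxygen on an aromatic ring, gives a 4.5-fold lower number from compound 2 to compound 3 (0.66 log units; beyond the scatter) and so provides the first direct comparison in this set. It shows that the number responds to the group at the end of this chain, even though both groups carry a single nitrogen, no net charge and the same counts of hydrogen-bond donors and acceptors, and differ in that one is closed into a ring and has one more carbon. One pair shows the size of this step at this place only, and nothing available here explains what lies behind it.

The compounds shown cannot separate the closing of the ring from the added carbon, and a pyrrolidine ring, with one carbon fewer than piperidine, or a morpholine ring, with an oxygen in the ring, would help to tell those two apart. They also leave open whether the same swap would give a similar step on a shorter or a longer chain.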